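Cytotoxicity notes on alkoxy variants of compound 1

The source may hold more compounds than are shown below. What is called first, only, known or untested is meant among the compounds shown, and "the series" means these compounds.

Compound 1 `C=CCOc1nc(N)nc2c1ncn2/C=C1/CC1(CO)CO` in an ADME assay on MOLT-3 cells (Homo sapiens) for cytotoxicity, with a stated time of 7 days (a higher number here means that more compound is tolerated, a lower number that less compound is tolerated), gives > 20000 nM, which is a limit of the assay and not a number.
Compound 2 `COCCOc1nc(N)nc2c1ncn2/C=C1/CC1(CO)CO` in this assay gives > 20000 nM, again a limit of the assay.
Compound 3 `CC(C)Nc1nc(N)nc2c1ncn2/C=C1/CC1(CO)CO` in this assay carries the entry "not determined" (no result reported), that is, no result reported.

Compound 1 stands only at a limit in this assay; of the two further entries, one is also a limit and one carries no number, so no ranking among the three is possible. Within the data shown here, the single step between measured compounds, a step that the two limits leave unreadable from compound 1 to compound 2, cannot be read, because both of its ends sit at the limit of > 20000 nM in this assay, at which 2 of the 3 values shown sit.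

Compound 4 `CCCCCOc1nc(N)nc2c1ncn2/C=C1/CC1(CO)CO` differs from compound 1 by butyl in place of vinyl on a saturated chain carbon bound to an oxygen on an aromatic ring. Among the measured compounds shown here, no measured step bears directly on this change: the step from compound 1 to compound 2 is the only one, and it is unreadable. With both measured analogues tolerated up to the limit, nothing in the series points to a readable shift in either direction, and the likeliest outcome for compound 4 is a further limit in this assay.

The expected step that the limit leaves unreadable from compound 1 to compound 4 is therefore no change beyond the scatter. Compound 4 is estimated at 25000 nM, with a range of 8000 nM to 60000 nM in this assay.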

Compound 4, half-maximal cytotoxic concentration: > 20000 nM
Compound 4: a limit, no number; the forecaster's own chance of this, stated with the estimate: 75%; the middle value lies beyond the limit too.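

Compound 4 sits at a limit of the assay, as do compound 1 and compound 2, so no step among these three can be read in this assay: the limit of > 20000 nM in this assay, at which 3 of the 4 values shown sit.

The compounds shown leave open how much compound is actually tolerated in each case, and whether the change from allyloxy to pentyloxy shifts that amount in either direction.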